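This account rests on a few compounds, and the source may have more. Where it says the series, first, only, none or still open, it means among the compounds named here.

Three compounds built on a shared core were tested in a functional assay on HeLa cells (Homo sapiens) for cytotoxicity, read by cell counting, with a stated time of 4 days; a higher number here means a weaker inhibitor, a lower number a stronger inhibitor. Compound 1 `C=C(Br)C(=O)Nc1cccc(/C=C2\SC(=O)N(Cc3ccc(Cl)cc3)C2=O)c1` gives 2700 nM, compound 3 `C=C(Br)C(=O)Nc1ccc(/C=C2\SC(=O)N(Cc3cccc(Cl)c3)C2=O)cc1` gives 8900 nM, and compound 2 `Nc1ccc(/C=C2\SC(=O)N(Cc3ccc(Cl)cc3)C2=O)cc1` gives 77000 nM. Compound 2 therefore stands with the highest number of the three, making it the weakest inhibitor here; its gaps to compound 3 and to compound 1 both lie beyond the scatter.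

Compound 4 `Nc1ccc(/C=C2\SC(=O)N(Cc3ccccc3)C2=O)cc1` differs from compound 2 in a single place: hydrogen in place of chloro on an aromatic carbon. Among the measured compounds shown here, no measured pair shows this same change, so its effect is unknown from the data at hand. A small step is expected, if anything toward a slightly higher number, and it may well stay within the scatter. The estimated step of a 1.3-fold higher number from compound 2 to compound 4 (0.11 log units; within the scatter) is expected to be modest. Compound 4 is expected at about 100000 nM, with a likely range from 40000 nM to 250000 nM.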

Compound 4, half-maximal inhibitory concentration: 46000 nM
Beside the measured number, compound 4's estimate is 2.2-fold (0.34 log units) above it; measured number inside the range.
By their numbers in this assay, from the lowest: compound 1; then compound 3; then compounds 4 and 2 (each within the scatter of the next).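

In this assay, going from 4-chlorophenyl to phenyl gives a 1.7-fold lower number from compound 2 to compound 4 (0.22 log units; within the scatter), so the chloro at this place can be swapped for hydrogen without a step beyond the scatter. The earlier compounds shown here could not show this, as no two of them differed in only one place. Nothing measured here explains the result.

From the compounds shown here alone, whether a methoxy group or a carboxylic acid at this place would leave the number as little moved remains open. So does whether the same change would read alike in compounds carrying the bromo-substituted amide of compound 1 instead of the free amine.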